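Nitro for fluorine on a shared core at the assay limit

The source may report more compounds than this note shows. Statements on the series, on what has been measured and on what is new or still open speak of the compounds shown alone.

Compound 1 `O=C(Nc1ccccc1F)c1ccc2cccc(O)c2n1` carries a fluorophenyl group on its amide nitrogen. In an ADME assay on THP-1 cells (Homo sapiens) for cytotoxicity, read by WST assay, with a stated time of 24 h (a lower number here means a stronger inhibitor, a higher number a weaker inhibitor), compound 1 gives > 30000 nM, which is a limit of the assay and not a number. Compound 2 `O=C(Nc1cccc(Cl)c1)c1ccc2cccc(O)c2n1` differs only in the aryl group on that nitrogen. In this assay compound 2 likewise gives a limit, > 30000 nM. Compound 3 `O=C(Nc1ccc(Br)cc1)c1ccc2cccc(O)c2n1` is the third variant, and in this assay compound 3 also gives a limit, > 30000 nM. All three values therefore sit at the same place (the limit of > 30000 nM in this assay, at which 3 of the 3 values shown sit), so the steps between them cannot be read: a step that the two limits leave unreadable from compound 1 to compound 2, a step that the two limits leave unreadable from compound 1 to compound 3 and a step that the two limits leave unreadable from compound 2 to compound 3.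

Compound 4 `O=C(Nc1ccccc1[N+](=O)[O-])c1ccc2cccc(O)c2n1` departs from compound 1 by nitro in place of fluoro on an aromatic carbon, a change on an aromatic carbon of a six-membered aromatic ring of carbon only, ortho to a large group. Among the compounds with values here, none of the measured steps gives a readable size, and every variation of the aryl group so far has left the value at the limit. Nothing here points to a step beyond the scatter for compound 4, and the expected change is a step that the limit leaves unreadable from compound 1 to compound 4. Compound 4 is accordingly expected to give about 40000 nM, between 15000 nM and 100000 nM, most likely reported again only as a limit.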

Compound 4, half-maximal inhibitory concentration: > 30000 nM
Compound 4 was reported as a limit (the forecaster's own chance of this, stated with the estimate: 85%); the middle value is on the limit's open side.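

In this assay compound 4 gives > 30000 nM, a limit of the assay and not a number. No step from compound 1 to compound 4 can be read, and compound 2 and compound 3 offer no readable comparison either: the limit of > 30000 nM in this assay, at which 4 of the 4 values shown sit.

The compounds shown leave open whether any aryl group on the amide nitrogen changes the cytotoxicity of the shared core.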